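The source may report more compounds than this note shows. Statements on the series, on what has been measured and on what is new or still open speak of the compounds shown alone.

Three compounds built around the core of compound 1 `O=C(CCc1ccccc1)NNc1c(Cl)cncc1Cl` have been run in a functional assay on HEK293 cells for antagonist activity at P2X purinoceptor 7 (Homo sapiens), read by fluorescence, with a stated time of 2 h; on this read-out higher numbers stand for weaker inhibition and lower numbers for stronger inhibition. In this assay compound 1 gives 650 nM, the lowest of the three numbers. Compound 3 `O=C(CCCCCCc1ccccc1)NNc1c(Cl)cncc1Cl` gives 950 nM, a number that lies within the scatter of compound 1. Compound 2 `O=C(CCc1ccccc1)NNc1c(Cl)cccc1Cl` gives 1400 nM, a number beyond the scatter and higher than that of compound 1. Compound 4 `O=C(CCC1CCCC1)NNc1c(Cl)cncc1Cl` has not yet been measured in this assay. It differs from compound 1 by cyclopentyl in place of phenyl on a saturated chain carbon, two bonds along the chain from a carbonyl carbon. Going by the values given here, no measured pair shows this exchange, so the expectation rests on compound 1 alone. The step this estimate means, a 1.7-fold higher number from compound 1 to compound 4 (0.23 log units; within the scatter), is expected to be small, at the edge of the scatter toward weaker inhibition. For compound 4 the estimated value is 1100 nM, with a range from 450 nM to 2700 nM.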

Compound 4, half-maximal inhibitory concentration: 380 nM
Estimate against measurement, compound 4: 2.9-fold (0.46 log units) above; the whole stated range lies above it.
By their numbers in this assay, from the lowest: compounds 4, 1, 3 and 2 (each within the scatter of the next, the first and the last beyond it).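

In this assay, cyclopentyl in place of phenyl on a saturated chain carbon, two bonds along the chain from a carbonyl carbon, gives a 1.7-fold lower number from compound 1 to compound 4 (0.23 log units; within the scatter). Between compound 1 and compound 4, then, the six-membered aromatic ring is not needed at this position: a five-membered non-aromatic ring of carbon only serves within the scatter. Nothing available explains this result.

On these data alone, whether an amine, a carboxylic acid or a cyclohexyl group would be tolerated at this position remains open. So does whether cyclopentyl would give a similar number on the longer chain of compound 3.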